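The compounds below may be only part of what the source reports. "The series", "measured", "known", "first", "only" and "open" are said of these compounds alone.

Compounds measured so far:
- compound 1, `COc1cc(SC)nc(NC(=S)NC(=O)c2c(-c3ccc(Cl)cc3Cl)noc2C)n1`: 60.3% in a functional assay on the whole organism for inhibition, with Chenopodium ficifolium as the target, with a stated time of 72 h, tested at 100 mg/L; a higher number here means more inhibition of growth at the concentration tested, a lower number less inhibition of growth
- compound 2, `Cc1onc(-c2ccc(Cl)cc2Cl)c1C(=O)/N=c1/nc2nc(Cl)cc(C)n2s1`: 73.6% in the same assay

Compound 1 stands at the lower of the two numbers. Among the measured compounds shown here, compound 2, which shares the dichlorophenyl-isoxazole part but carries a different core, gives the higher number, and the gap between the two lies beyond the usual scatter of this assay; no structural step connects the pair, so only the two values themselves can be compared.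

Compound 3, `COc1cc(OC)nc(NC(=S)NC(=O)c2c(-c3ccc(Cl)cc3Cl)noc2C)n1`, is the compound still to be tested. It differs from compound 1 in one place: methoxy in place of methylsulfanyl on an aromatic carbon. The change sits on the aromatic carbon next to the ring nitrogen, meta to a large group and meta to the other methoxy group, so both substituents on that ring become the same. For the measured compounds named here, no measured pair shows this exchange, so its effect cannot be read from the data. He expects a step from compound 1 to compound 3 of a number 2.3 percentage points lower from compound 1 to compound 3 (within the scatter), that is, nothing clearly beyond the scatter in either direction. His estimate for compound 3 in this assay is 58%, with a range from 40% to 76%.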

Compound 3, percent growth inhibition at one concentration: 78.6%
For compound 3 the middle estimate is 20.6 percentage points below the measured one, outside the stated range (above it).
By their numbers in this assay, from the lowest: compound 1; then compounds 2 and 3 (each within the scatter of the next).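

In this assay, among the compounds shown here, the exchange of methylsulfanyl for methoxy on the aromatic carbon next to the ring nitrogen is the first change in one place that can be read, and it gives a number 18.3 percentage points higher from compound 1 to compound 3 (beyond the scatter) with the rest of the molecule unchanged. This shows that the position is not indifferent to its substituent: the two groups match in their counts of heavy atoms and hydrogen-bond acceptors and differ in sulfur against oxygen, yet the read-out moves beyond the scatter, and the 4,6-dimethoxypyrimidin-2-yl compound comes out ahead of its 4-methoxy-6-(methylsulfanyl)pyrimidin-2-yl partner. Nothing available on these compounds explains the step.

The compounds shown leave open how an amine, an ethoxy group or a chlorine atom at this position would compare with methoxy, and what role the other methoxy group on the ring plays in the step. Going by these compounds, they also rest on a single pair in one plant species at one tested concentration, so it remains open whether the same exchange would carry the same step in another species or on another core.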